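This account rests on a few compounds, and the source may have more. Where it says the series, first, only, none or still open, it means among the compounds named here.

Compound 1 `CCOC(=O)n1nc(N)c(/N=N/c2ccc(O)cc2)c1N`: > 100000 nM
Compound 2 `Nc1n[nH]c(N)c1/N=N/c1cc[n+]([O-])cc1`: > 100000 nM

In a functional assay on K562 cells (Homo sapiens) for cytotoxicity, read by fluorescence, with a stated time of 72 h (on this read-out higher numbers stand for weaker inhibition and lower numbers for stronger inhibition), compound 1 gives > 100000 nM, which is a limit of the assay and not a number. Compound 2 gives > 100000 nM, again a limit. Compound 1 therefore stands with compound 2 at the limit of > 100000 nM in this assay, at which 2 of the 2 values shown sit. Going by the values given here, no measured pair shows how a single structural change moves this read-out.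

Compound 3 `CC(=O)n1nc(N)c(/N=N/c2ccc(O)cc2)c1N` departs from compound 1 at one place: methyl in place of ethoxy on a carbonyl carbon. This puts methyl in place of ethoxy on a carbonyl carbon, so ethoxycarbonyl becomes acetyl.

The expectation rests on compound 1 and its limit of > 100000 nM. The expected change is a number no higher from compound 1 to compound 3 (the limit leaves the size open), which means no step beyond the scatter in this assay and no favoured direction. Another reading at the limit is considered likely. For compound 3 the estimated value is 100000 nM, with an expected range from 40000 nM to 250000 nM.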

Compound 3, half-maximal inhibitory concentration: 64900 nM
For compound 3 the middle estimate is 1.5-fold (0.19 log units) above the measured one, and the stated range covers the measured number.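

In this assay compound 3 gives 64900 nM, the only reading of the three shown that is a number and not a limit. This places a measurable reading at this carbonyl carbon, where methyl replaces ethoxy and ethoxycarbonyl becomes acetyl. The change gives an at least 1.5-fold lower number from compound 1 to compound 3 (0.18 log units; that floor lies within the scatter), so the step has only a floor, and that floor alone does not establish a real change: the limit of > 100000 nM in this assay, at which 2 of the 3 values shown sit.

The step rests on a limit. Its true size stays open, and the compounds shown offer no explanation for the reading of compound 3. They also leave open how a propyl chain or an amino group on this carbonyl carbon would read in this assay.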